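Fluoro to methyl swap on the benzyl group

The compounds below may be only part of what the source reports. "The series", "measured", "known", "first", "only" and "open" are said of these compounds alone.

The series shares one core; compound 1 `COC(=O)c1ccc(NCc2cncn2Cc2ccccc2N)cc1-c1ccccc1`, compound 2 `COC(=O)c1ccc(NCc2cncn2Cc2ccc(C)cc2)cc1-c1ccccc1` and compound 3 `COC(=O)c1ccc(NCc2cncn2Cc2ccccc2F)cc1-c1ccccc1` differ only in the substituent on the benzyl group. Within the data shown here, in a toxicity assay on NIH3T3 cells (Mus musculus) for cytotoxicity, read by resazurin assay (on this read-out lower numbers stand for an effect already at smaller amounts and higher numbers for an effect only at larger amounts of compound), compound 1 gives 25000 nM, and compound 2 gives 50000 nM; the single step measured so far, a 2.0-fold higher number from compound 1 to compound 2 (0.30 log units; within the scatter), is the only guide to how this position behaves. Compound 3 carries the 2-fluorobenzyl group, but in this assay compound 3 has no result: "not determined" (no result reported). It therefore stands nowhere on the numbers shown, and any expectation for its neighbour must rest on compounds 1 and 2 alone.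

Compound 4 `COC(=O)c1ccc(NCc2cncn2Cc2ccccc2C)cc1-c1ccccc1` differs from compound 3 by methyl in place of fluoro on an aromatic carbon, that is, 2-fluorobenzyl becomes 2-methylbenzyl. Among the measured compounds shown here, no measured step covers this exchange. For the measured compounds named here, the one step available, from a 2-aminophenyl to a 4-methylphenyl group, stayed within the scatter, so nothing suggests that a change at this position moves the read-out much. For this assay no step beyond the scatter is expected for compound 4 relative to compounds 1 and 2. Compound 4 is estimated at 35000 nM, expected to fall between 12000 nM and 100000 nM, given that compound 1 sits at 25000 nM and compound 2 at 50000 nM.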

Compound 4, half-maximal effective concentration: 10000 nM
The estimate for compound 4 lay 3.5-fold (0.54 log units) above the measured number; the whole stated range lies above it.
By their numbers in this assay, from the lowest: compound 4; then compounds 1 and 2 (each within the scatter of the next).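

Moving the methyl alone, with 2-methylphenyl in place of 4-methylphenyl, gives a 5.0-fold lower number from compound 2 to compound 4 (0.70 log units; beyond the scatter) in this assay, so on the benzyl group the place of a substituent can shift the read-out beyond the scatter even when the substituent stays the same. Methyl in place of amino on an aromatic carbon gives a 2.5-fold lower number from compound 1 to compound 4 (0.40 log units; beyond the scatter) as well, which sets compound 4 beyond the scatter of both earlier compounds, while compound 1 and compound 2 remain within the scatter of each other. The fluoro to methyl exchange itself cannot be read, as compound 3 has no result, and nothing at hand accounts for the shift seen with compound 4.

Still open, going by these compounds, is whether the lower number goes with the methyl group specifically or would also appear with another group in its place, such as chloro, methoxy, ethyl or trifluoromethyl on the benzyl group. Among these compounds, also open is whether the step between compound 2 and compound 4 holds for other substituents, since methyl is the only group here seen in two places on the benzyl group.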